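This account rests on a few compounds, and the source may have more. Where it says the series, first, only, none or still open, it means among the compounds named here.

Readings in a functional assay on A549 cells (Homo sapiens) for cytotoxicity, read by MTT assay, with a stated time of 72 h; on this read-out lower numbers stand for stronger inhibition and higher numbers for weaker inhibition:
- compound 1 `COc1cc2ncnc(Nc3ccc(F)c(Cl)c3)c2cc1NC(=O)/C=C/c1ccccc1[N+](=O)[O-]`: 33300 nM
- compound 2 `N#Cc1ccc(/C=C/C(=O)Nc2cc3c(Nc4ccc(F)c(Cl)c4)ncnc3cc2O[C@H]2CCOC2)cc1`: "not active" (no number reported)
- compound 3 `COc1cc2ncnc(Nc3ccc(F)c(Cl)c3)c2cc1NC(=O)/C=C/c1ccc(C#N)cc1`: "not active" (no number reported)

Awaiting measurement: compound 4 `COc1cc(/C=C/C(=O)Nc2cc3c(Nc4ccc(F)c(Cl)c4)ncnc3cc2O[C@H]2CCOC2)cc(OC)c1`.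

Compound 2 has no single number on this read-out, as it is reported only as "not active" (no number reported). Compound 3 carries the same entry, "not active" (no number reported). For the measured compounds named here, the only number in the set belongs to compound 1, at 33300 nM, so compound 2 can be placed only alongside compound 3 and not on a scale.

The change under review is 3,5-dimethoxyphenyl in place of 4-cyanophenyl on a double-bonded chain carbon bound to a double-bonded chain carbon. Cut one bond further out, it reads 2-(4-cyanophenyl)ethenyl to 2-(3,5-dimethoxyphenyl)ethenyl, and the rest of the structure stays the same.

Going by the values given here, no measured step in this assay shows what such an exchange does, and a step away from a reading without a number cannot be sized. The expectation is therefore a weak result with no large gain, resting on compound 1 at 33300 nM and compound 3 at "not active" (no number reported). Compound 4 is estimated at 40000 nM, with an expected range of 15000 nM to 100000 nM.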

Compound 4, half-maximal inhibitory concentration: 10800 nM
Beside the measured number, compound 4's estimate is 3.7-fold (0.57 log units) above it; measured number outside the range, below it.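

In this assay compound 4 gives 10800 nM and compound 2 gives "not active" (no number reported), so no step can be read between them. Nothing available bears on the cause of this result. The compounds shown leave open how large the change from 4-cyanophenyl to 3,5-dimethoxyphenyl is on this read-out.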